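The source may hold more compounds than are shown below. What is called first, only, known or untested is meant among the compounds shown, and "the series" means these compounds.

Three measured compounds share one core and differ only in the group on the sulfonyl sulfur. Compound 1 `CC1=NC(c2cn(S(=O)(=O)c3ccc(Cl)cc3)c3ccc(C)cc23)CN1` carries a 4-chlorophenyl there. In an assay on isolated protein for inhibition of kallikrein-7 (Mus musculus), read by fluorescence, with stated times of 10 min and 30 min (on this read-out higher numbers stand for weaker inhibition and lower numbers for stronger inhibition), compound 1 gives > 100000 nM, which is a limit of the assay and not a number. Compound 2 `CC1=NC(c2cn(S(=O)(=O)c3cccs3)c3ccc(C)cc23)CN1` carries a thiophen-2-yl, and in this assay compound 2 gives 22000 nM; the step of an at least 4.5-fold lower number from compound 1 to compound 2 (0.65 log units; beyond the scatter) lies beyond the scatter. Compound 3 `CC1=NC(c2cn(S(=O)(=O)c3ccc(F)cc3)c3ccc(C)cc23)CN1` carries a 4-fluorophenyl. In this assay compound 3 gives > 30000 nM, again only a limit. Thus compound 3 stands with a limit rather than a number, and one further value shown is also a limit. The step that the two limits leave unreadable from compound 1 to compound 3 cannot be read, and the step of an at least 1.3-fold higher number from compound 2 to compound 3 (0.13 log units; that floor lies within the scatter) has a floor within the scatter.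

Compound 4 `CC1=NC(c2cn(S(=O)(=O)c3ccccc3F)c3ccc(C)cc23)CN1` differs from compound 3 by 2-fluorophenyl in place of 4-fluorophenyl on a sulfonyl sulfur. For the measured compounds named here, no measured step shifts a fluorine to another place on the ring; the steps that touch this ring, a step that the two limits leave unreadable from compound 1 to compound 3 and an at least 1.3-fold higher number from compound 2 to compound 3 (0.13 log units; that floor lies within the scatter), are both unreadable beyond the scatter. Compound 4 is therefore expected to show no step beyond the scatter, roughly a step that the limit leaves unreadable from compound 3 to compound 4. Compound 4 is estimated at 40000 nM, within 10000 nM to 150000 nM.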

Compound 4, half-maximal inhibitory concentration: 6400 nM
The estimate for compound 4 lay 6.3-fold (0.80 log units) above the measured number; the whole stated range lies above it.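

Changing only where the fluorine sits on the phenyl ring, with the same atoms present, matters here: 2-fluorophenyl in place of 4-fluorophenyl gives an at least 4.6-fold lower number from compound 3 to compound 4 (0.67 log units; beyond the scatter) in this assay. Compound 4 is also the strongest inhibitor of the four, with a 3.4-fold lower number from compound 2 to compound 4 (0.54 log units; beyond the scatter) and an at least 15-fold lower number from compound 1 to compound 4 (1.19 log units; beyond the scatter), so a halogen-bearing phenyl on the sulfonyl sulfur need not be the weaker choice against thiophen-2-yl. The step from the 4-fluorophenyl compound gives only a floor, not a full size, because the value of compound 3 is a limit: the limit of > 30000 nM in this assay, at which 1 of the 4 values shown sits.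

The compounds shown leave open whether fluorine itself matters, or whether a methoxy group or an amine in place of the fluorine would serve as well. They also cannot say why the place of the fluorine changes the number, or how a longer chain on the sulfonyl sulfur would behave.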